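From Amino to Methyl at the Assay Limit

The compounds below may be only part of what the source reports. "The series", "measured", "known", "first", "only" and "open" are said of these compounds alone.

In a functional assay on MCF7 cells (Homo sapiens) for cytotoxicity, read by MTT assay, with a stated time of 48 h (a lower number here means a stronger inhibitor, a higher number a weaker inhibitor), compound 1 (`COc1ccc(Nc2nc(-c3cccc(F)c3)nc3ccc(F)cc23)cc1`) gives 48400 nM. Compound 2 (`COc1ccccc1Nc1nc(-c2cccc(F)c2)nc2ccc(F)cc12`) reads > 50000 nM, which is a limit and not a number. Compound 3 (`Nc1ccc(Nc2nc(-c3cccc(F)c3)nc3ccc(F)cc23)cc1`) reads > 50000 nM, which is likewise a limit. Compound 3 therefore has no measured number and stands only at the limit of > 50000 nM in this assay, at which 2 of the 3 values shown sit.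

Compound 4 (`Cc1ccc(Nc2nc(-c3cccc(F)c3)nc3ccc(F)cc23)cc1`) differs from compound 3 by one change: methyl in place of amino on an aromatic carbon. In words, this is methyl in place of amino on an aromatic carbon, para to a large group.

Going by the values given here, no measured step makes this exact change. The nearest is an at least 1.0-fold higher number from compound 1 to compound 3 (0.01 log units; that floor lies within the scatter), which puts amino in place of methoxy on an aromatic carbon. The step of an at least 1.0-fold higher number from compound 1 to compound 2 (0.01 log units; that floor lies within the scatter) moves the methoxy group and gives only a floor as well, while a step that the two limits leave unreadable from compound 2 to compound 3 says nothing about size. With compound 1 at 48400 nM as the only numerical anchor, the new value is expected to fall close to that of compound 1. The estimate is an at least 1.2-fold lower number from compound 3 to compound 4 (0.09 log units; that floor lies within the scatter), which means little or nothing beyond the scatter and, if anything, a lower number in this assay. The expected value for compound 4 is 40000 nM, with an estimated range of 15000 nM to 80000 nM.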

Compound 4, half-maximal inhibitory concentration: > 50000 nM
Compound 4 gave a limit, no number; the forecaster's own chance of this, stated with the estimate: 50%; at least 1.2-fold (0.09 log units) between middle value and limit.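

In this assay compound 4 reads > 50000 nM, which is a limit of the assay and not a number. With methyl, as with amino, this aromatic carbon para to a large group gives no measured number, so taking away the hydrogen-bond donor and acceptor counted for amino leaves the reading at the same limit: the limit of > 50000 nM in this assay, at which 3 of the 4 values shown sit. Going by these compounds alone, the one step that can be read is an at least 1.0-fold higher number from compound 1 to compound 4 (0.01 log units; that floor lies within the scatter), so the data do not separate methyl from methoxy at this position, and the steps to compound 4 from compound 2 and from compound 3 cannot be read.

On these data alone, how far compound 2, compound 3 and compound 4 lie past the limit stays open. As far as these compounds go, it is also open whether a chlorine, a hydroxyl or a carboxylic acid on this same carbon would give a clearly lower number than compound 1, which reads 48400 nM.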